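Hydroxy on the sulfonamide propyl chain of compound 2

This account rests on a few compounds, and the source may have more. Where it says the series, first, only, none or still open, it means among the compounds named here.

Measured so far:
compound 1 `CC[C@@H]1C(=O)N(C)c2cnc(-n3ccc4cc(C(N)=O)ccc43)nc2N1C1CCCC1` — 28.5 nM
compound 2 `CCCNS(=O)(=O)c1ccc(Nc2ncc3c(n2)N(c2ccn(C)n2)C(CC)C(=O)N3C)cc1` — 190 nM

In an assay for inhibition of serine/threonine-protein kinase PLK2 (Homo sapiens), read by FRET and Z'-LYTE, with a stated time of 1 h (a lower number here means a stronger inhibitor, a higher number a weaker inhibitor), compound 2 gives 190 nM, the higher of the two numbers; its nearest neighbour, compound 1, gives 28.5 nM, a gap that lies beyond the scatter. Compound 3 `CCC1C(=O)N(C)c2cnc(Nc3ccc(S(=O)(=O)NCCCO)cc3)nc2N1c1ccn(C)n1` carries hydroxy in place of hydrogen on a saturated chain carbon, three bonds along the chain from a sulfonamide nitrogen. Among the measured compounds shown here, no step between measured compounds covers this kind of change, so no shift beyond the scatter is expected; the step of no change at the digits printed from compound 2 to compound 3 (within the scatter) is estimated as essentially flat, with the range widened for the lack of a precedent. Compound 3 is expected at 190 nM, from 70 nM to 500 nM.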

Compound 3, half-maximal inhibitory concentration: 192 nM
The estimate for compound 3 lay 1.0-fold (0.00 log units) below the measured number, and the stated range covers the measured number.
By their numbers in this assay, from the lowest: compound 1; then compounds 2 and 3 (each within the scatter of the next).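

In this assay, the change from propyl to 3-hydroxypropyl gives a 1.0-fold higher number from compound 2 to compound 3 (0.00 log units; within the scatter), so this chain position accepts a hydroxy without a shift beyond the scatter. Among the compounds shown here, this is the first single-place step, and it sets a flat baseline for this position. No separate data bear on the reason for this flat step.

As far as these compounds go, whether an amine or a carboxylic acid in place of the hydroxy would leave the number as flat remains open. So does the effect of a longer chain carrying the hydroxy.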